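This account rests on a few compounds, and the source may have more. Where it says the series, first, only, none or still open, it means among the compounds named here.

Working notes on the boronic-acid series

The series shares one core; compound 1 is `Cc1cccc(C(=O)/C=C/c2ccc3c(c2)B(O)OC3)c1`, compound 2 is `COc1cccc(C(=O)CCc2ccc3c(c2)B(O)OC3)c1`, and compound 3 is `COCOc1ccccc1C(=O)/C=C/c1ccc2c(c1)B(O)OC2`. All three have been run in an ADME assay on L929 cells (Mus musculus) for cytotoxicity, read by resazurin assay, with a stated time of 72 h; a higher number here means a weaker inhibitor, a lower number a stronger inhibitor. Compound 1 gives 8.56 ug/mL in this assay. Compound 3 gives 9.02 ug/mL in this assay. From the compounds shown here alone, for compound 2 the result in this assay is a limit of the measurement and not a number: compound 2 gives > 10 ug/mL, so the compound sits at the limit of > 10 ug/mL in this assay, at which 1 of the 3 values shown sits, and its true value is unknown.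

The next compound, compound 4, is `O=C(CCc1ccc2c(c1)B(O)OC2)c1ccccc1`; it has not been measured in this assay. It differs from compound 2 in one place, (hydrogen in place of methoxy on an aromatic carbon). Going by the values given here, no measured pair shows a change of this kind, so there is no step to lean on.

Because compound 2 stands at the limit of > 10 ug/mL in this assay, at which 1 of the 3 values shown sits, the step from compound 2 to compound 4 is expected to be small, with no clear direction beyond the scatter; the estimated step is a number no higher from compound 2 to compound 4 (the limit leaves the size open). Compound 4 is accordingly estimated at 10 ug/mL in this assay, in a range from 6 ug/mL to 20 ug/mL, with a real chance that only a limit is again reported.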

Compound 4, half-maximal inhibitory concentration: > 10 ug/mL
Compound 4 gave a limit, no number; the forecaster's own chance of this, stated with the estimate: 50%; the middle value sits exactly at the limit.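

No step from compound 2 to compound 4 can be read in this assay, because each compound gave only a limit and not a number: the limit of > 10 ug/mL in this assay, at which 2 of the 4 values shown sit.

The compounds shown leave open whether hydrogen in place of methoxy on an aromatic carbon changes the result in either direction, and by how much.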